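Chloropyrimidinyl Piperazine Ureas: Methoxy in Place of Isopropyl

This account rests on a few compounds, and the source may have more. Where it says the series, first, only, none or still open, it means among the compounds named here.

Measured so far in an assay on isolated protein for antagonist activity at transient receptor potential cation channel subfamily V member 1 (Homo sapiens); on this read-out lower numbers stand for stronger inhibition and higher numbers for weaker inhibition: compound 1 `O=C(Nc1cccc(F)c1)N1CCN(c2ccnc(Cl)n2)CC1` gives 952 nM; compound 2 `O=C(Nc1ccc(F)cc1)N1CCN(c2ccnc(Cl)n2)CC1` gives 1140 nM; compound 3 `CC(C)c1ccccc1NC(=O)N1CCN(c2ccnc(Cl)n2)CC1` gives 7530 nM.

Compound 3 stands highest of the three numbers, and its gaps to compound 2 and to compound 1 both lie beyond the scatter. Compound 4 `COc1ccccc1NC(=O)N1CCN(c2ccnc(Cl)n2)CC1` differs from compound 3 by methoxy in place of isopropyl on an aromatic carbon. Among the measured compounds shown here, the only measured step, a 1.2-fold higher number from compound 1 to compound 2 (0.08 log units; within the scatter), moves a fluorine on the phenyl and lies within the scatter, so no step speaks to exchanging a group on this aromatic carbon. A lower number is nonetheless expected for compound 4, because compound 3 gives 7530 nM whereas compound 2 gives 1140 nM, and the methoxy keeps the ring substituted ortho to a large group. Compound 4 is therefore estimated at 2500 nM, with a range from 700 nM to 9000 nM, an expected step of a 3.0-fold lower number from compound 3 to compound 4 (0.48 log units; beyond the scatter).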

Compound 4, half-maximal inhibitory concentration: 9420 nM
Compound 4: middle estimate off by 3.8-fold (0.58 log units), on the low side; the measured number lies above the stated range.
By their numbers in this assay, from the lowest: compounds 1 and 2 (each within the scatter of the next); then compounds 3 and 4 (each within the scatter of the next).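

Methoxy and isopropyl on this aromatic carbon, ortho to a large group, are not told apart in this assay (a 1.3-fold higher number from compound 3 to compound 4 (0.10 log units; within the scatter)). Compound 4 stands well clear of both fluorophenyl compounds (an 8.3-fold higher number from compound 2 to compound 4 (0.92 log units; beyond the scatter); a 9.9-fold higher number from compound 1 to compound 4 (1.00 log units; beyond the scatter)), so the high number of compound 3 is not confined to isopropyl. No evidence is available that bears on this result. The compounds shown leave open whether an amine or a hydroxyl on this aromatic carbon would give a number apart from those of compound 3 and compound 4.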